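The compounds below may be only part of what the source reports. "The series", "measured", "known", "first", "only" and "open" are said of these compounds alone.

Compound 1 `Cc1[nH]cnc1CN1CCN(c2ccccc2)C1=O`: 26.9 nM
Compound 2 `Cc1[nH]cnc1CN1CCN(c2cccc(F)c2)C1=O`: 88.3 nM

Both were tested in a functional assay (Cavia porcellus) for antagonist activity at Serotonin 3 (5-HT3) receptor (Homo sapiens); a lower number here means a stronger inhibitor, a higher number a weaker inhibitor. Among the compounds with values here, compound 2 stands at the higher of the two numbers, set apart from compound 1 by the only step measured so far, a 3.3-fold higher number from compound 1 to compound 2 (0.52 log units; beyond the scatter), a fluoro in place of hydrogen on an aromatic carbon. Compound 3 `COc1cccc(N2CCN(Cc3nc[nH]c3C)C2=O)c1` carries the change (methoxy in place of fluoro on an aromatic carbon), meta to a large group. Within the data shown here, no measured step covers a methoxy, so that single step is the only guide, and it points toward weakening at this position. Compound 3 is expected to come out somewhat weaker, a 1.5-fold higher number from compound 2 to compound 3 (0.17 log units; within the scatter). Compound 3 is therefore estimated at 130 nM, likely between 40 nM and 450 nM.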

Compound 3, antagonist equilibrium constant: 67.8 nM
Estimate against measurement, compound 3: 1.9-fold (0.28 log units) above, within the range that was stated.
By their numbers in this assay, from the lowest: compound 1; then compounds 3 and 2 (each within the scatter of the next).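

In this assay, methoxy in place of fluoro gives a 1.3-fold lower number from compound 2 to compound 3 (0.11 log units; within the scatter), so this position does not separate the two groups, even though methoxy adds a heavy atom and a hydrogen-bond acceptor. Methoxy in place of hydrogen gives a 2.5-fold higher number from compound 1 to compound 3 (0.40 log units; beyond the scatter), so, like fluoro, it leaves the number higher than hydrogen does on this carbon. No measurement at hand accounts for this result. From the compounds shown here alone, whether an amine or a carboxylic acid on this carbon would also raise the number remains open, as does the effect of fluoro or methoxy on other carbons of this ring.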